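The source may hold more compounds than are shown below. What is called first, only, known or untested is meant among the compounds shown, and "the series" means these compounds.

Measured so far in a functional assay on U-87MG ATCC cells (Homo sapiens) for cytotoxicity, read by MTT assay, with a stated time of 48 h; a higher number here means a weaker inhibitor, a lower number a stronger inhibitor:
- compound 1 `C/C(=N/NC(=S)Nc1ccccc1)c1ccccn1` gives 1.4 nM
- compound 2 `CC(=NNC(=S)Nc1ccc(I)cc1)c1ccccn1` gives 59 nM

Compound 2, at 59 nM, holds the higher of the two numbers and is therefore the weaker inhibitor of the pair. Among the compounds with values here, compound 1 is the only neighbour on the scale, at 1.4 nM, and the gap between the two values lies well beyond the usual scatter.

The next compound to be read is compound 3 `C/C(=N/NC(=S)Nc1ccc(I)cc1)c1ccccn1`. Its difference from compound 2 is the two compounds have the same atoms and bonds; at least one stereo element is drawn with a configuration in one of them and without one in the other: 1 of 1 stereo elements differ; a double bond is drawn without a configuration in compound 2 and Z in compound 3. Within the data shown here, the two compounds have the same atoms and bonds, and the only change lies in how one double bond is drawn: without a configuration in compound 2 and Z in compound 3.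

Among the measured compounds shown here, the series holds no measured step of this kind, so no size can be taken from the data. With nothing entering or leaving, no shift in either direction beyond the scatter is expected in this assay, and the anchor is compound 2 at 59 nM. The expected change is a 1.2-fold lower number from compound 2 to compound 3 (0.07 log units; within the scatter), which would stay within the scatter. For compound 3 the estimated value is 50 nM, with an expected range from 12 nM to 150 nM.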

Compound 3, half-maximal inhibitory concentration: 59 nM
For compound 3 the middle estimate is 1.2-fold (0.07 log units) below the measured one; measured number inside the range.
By their numbers in this assay, from the lowest: compound 1; then compounds 2 and 3 (each within the scatter of the next).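

In this assay the step for the double bond reads no change at the digits printed from compound 2 to compound 3 (within the scatter), so drawing a Z configuration instead of none does not separate these two compounds. Compound 3 therefore gives the series its first comparison that differs in one place only, and iodo in place of hydrogen on an aromatic carbon comes with a 42-fold higher number from compound 1 to compound 3 (1.62 log units; beyond the scatter), a large penalty now seen without any difference in how the double bond is drawn. The agreement between compound 2 and compound 3 has to be read against the only thing that separates them, which is a matter of drawing and not of atoms or bonds: the fact that one of compounds 2 and 3 is drawn with a defined configuration and the other without, at the place where they differ

Going by these compounds, with only hydrogen and iodo compared at this aromatic carbon, it remains open whether a smaller halogen such as fluoro, or a group such as methoxy or an amine, would give a number nearer to compound 1 or to compound 3. The compounds shown also leave open how the opposite configuration of the double bond would read, as neither compound 1 nor compound 3 carries it.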